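A few compounds are considered here, and "the series" means these few. Any claim that something is new, unique, unknown or untested is made for them only; others in the source may bear on it.

In a functional assay on HepG2 cells (Homo sapiens) for antiproliferative activity, read by MTT assay, with a stated time of 24 h (on this read-out lower numbers stand for stronger inhibition and higher numbers for weaker inhibition), the three measured compounds span a modest range. Compound 1 `Cc1ccccc1-n1cc(-c2ccccc2NS(=O)(=O)c2c[nH]c(=O)[nH]c2=O)nn1` gives 13900 nM. Compound 2 `O=c1[nH]cc(S(=O)(=O)Nc2ccccc2-c2cn(-c3ccccc3Cl)nn2)c(=O)[nH]1` gives 2240 nM, and compound 3 `O=c1[nH]cc(S(=O)(=O)Nc2ccccc2-c2cn(-c3cccc(Cl)c3)nn2)c(=O)[nH]1` gives 2460 nM. Compound 3 stands second highest of the three; its number lies within the scatter of that of compound 2, while the step of a 5.7-fold lower number from compound 1 to compound 3 (0.75 log units; beyond the scatter) is beyond the scatter, as is the parallel step a 6.2-fold lower number from compound 1 to compound 2 (0.79 log units; beyond the scatter).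

Compound 4 `O=c1[nH]cc(S(=O)(=O)Nc2ccccc2-c2cn(-c3ccc(Cl)cc3)nn2)c(=O)[nH]1` has the same atoms as compound 3, joined differently: 4-chlorophenyl in place of 3-chlorophenyl on an aromatic nitrogen. The measured step that bears most directly on this change is a 1.1-fold higher number from compound 2 to compound 3 (0.04 log units; within the scatter), in which the chlorine was also moved from one position of the phenyl ring to another while everything else stayed fixed, and the number barely moved. Only one such move has been measured, so the expectation rests on a single comparison, but it points to no step beyond the scatter in this assay .

On that basis the step of a 1.0-fold higher number from compound 3 to compound 4 (0.01 log units; within the scatter) is expected to be small. Compound 4 is therefore estimated to give 2500 nM in this assay , within a range from 1100 nM to 5600 nM.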

Compound 4, half-maximal inhibitory concentration: 1840 nM
Compound 4: middle estimate off by 1.4-fold (0.13 log units), on the high side, within the range that was stated.
By their numbers in this assay, from the lowest: compounds 4, 2 and 3 (each within the scatter of the next); then compound 1.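

The 2-chlorophenyl, 3-chlorophenyl and 4-chlorophenyl groups on the aromatic nitrogen can now be compared as a full set in this assay, and both a 1.3-fold lower number from compound 3 to compound 4 (0.13 log units; within the scatter) and a 1.2-fold lower number from compound 2 to compound 4 (0.09 log units; within the scatter) stay within the scatter. Moving the chlorine around this phenyl ring therefore gives no difference that this read-out can resolve among compound 2, compound 3 and compound 4. The separation from the 2-methylphenyl group also holds for this third chloro compound, with a 7.6-fold lower number from compound 1 to compound 4 (0.88 log units; beyond the scatter), so all three chloro compounds lie on the same side of compound 1 and none goes against that pattern.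

No measurement shown explains why the place of the chlorine matters so little here or why compound 1 stands apart. Still open, on these data alone, is whether a methoxy group, an amine or a carboxylic acid in place of the chlorine would keep the number in this range, and whether 3-methylphenyl or 4-methylphenyl would stand apart from the chloro compounds as the 2-methylphenyl group of compound 1 does.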